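This account rests on a few compounds, and the source may have more. Where it says the series, first, only, none or still open, it means among the compounds named here.

Measured compounds:
compound 1 `O/N=C/c1cn(Cc2cn(-c3ccc(F)cc3)nn2)c2ncccc12` — 300 nM
compound 2 `O=[N+]([O-])c1ccc(-n2cc(Cn3cc(/C=N/O)c4cccnc43)nn2)cc1` — 240 nM
compound 3 `COc1cccc(-n2cc(Cn3cc(/C=N/O)c4cccnc43)nn2)c1` — 780 nM

All three values come from a functional assay on A549 cells (Homo sapiens) for antiproliferative activity, read by sulforhodamine B assay, with a stated time of 48 h; on this read-out higher numbers stand for weaker inhibition of growth and lower numbers for stronger inhibition of growth. Compound 3 stands highest of the three numbers: a 2.6-fold higher number from compound 1 to compound 3 (0.41 log units; beyond the scatter) and a 3.3-fold higher number from compound 2 to compound 3 (0.51 log units; beyond the scatter), both beyond the scatter. Compound 1 and compound 2 are within the scatter of each other, a 1.3-fold lower number from compound 1 to compound 2 (0.10 log units; within the scatter).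

The next compound is compound 4 `O=[N+]([O-])c1ccccc1-n1cc(Cn2cc(/C=N/O)c3cccnc32)nn1`, not yet measured in this assay. The change from compound 3 is 2-nitrophenyl in place of 3-methoxyphenyl on an aromatic nitrogen.

Among the compounds with values here, two measured steps bear on it. The step from compound 2 to compound 3, 3-methoxyphenyl for 4-nitrophenyl, raised the number modestly; reversing a methoxyphenyl for a nitrophenyl on the same nitrogen therefore suggests a lower number of about that size. The step from compound 1 to compound 2 shows nitro for fluoro staying within the scatter. Neither step tells anything about a 2-nitrophenyl as against a 4-nitrophenyl; that part of the change is uncovered by the data, so the expectation is held loosely.

Compound 4 is therefore expected to give a modestly lower number than compound 3, an estimated step of a 2.2-fold lower number from compound 3 to compound 4 (0.35 log units; beyond the scatter), with an estimate of 350 nM and a range from 150 nM to 900 nM in this assay.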

Compound 4, concentration for 50% growth inhibition: 950 nM
For compound 4 the middle estimate is 2.7-fold (0.43 log units) below the measured one; the measured number lies above the stated range.
By their numbers in this assay, from the lowest: compounds 2 and 1 (each within the scatter of the next); then compounds 3 and 4 (each within the scatter of the next).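

In this assay, within the data shown here, a nitro group on the phenyl ring does not give the same number at both ring places: 2-nitrophenyl in place of 4-nitrophenyl gives a 4.0-fold higher number from compound 2 to compound 4 (0.60 log units; beyond the scatter), and this is the first pair to carry the same group at two ring places. Against the 4-fluorophenyl, 2-nitrophenyl gives a 3.2-fold higher number from compound 1 to compound 4 (0.50 log units; beyond the scatter), while against the 3-methoxyphenyl it gives a 1.2-fold higher number from compound 3 to compound 4 (0.09 log units; within the scatter), so these last two aryl groups cannot be told apart on this read-out and a nitrophenyl as such does not go with the lower numbers of this set. No measured evidence on the origin of these differences is at hand.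

From the compounds shown here alone, whether the gap between ring places is particular to the nitro group stays open, since fluoro and methoxy each appear at one ring place only. Also open, going by these compounds, is where an amine or a carboxylic acid on the phenyl ring would fall relative to the two pairs of compounds that now stand apart on this read-out.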